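Methylating the Ring Nitrogen of Compound 1

The source may hold more compounds than are shown below. What is called first, only, known or untested is meant among the compounds shown, and "the series" means these compounds.

Compound 1 `O=C(Nc1ccc(Oc2ccnc3[nH]ccc23)cc1)c1nn(-c2ccccc2)ccc1=O`: 17800 nM
Compound 2 `O=C(Nc1ccc(Oc2ccnc3[nH]ccc23)c(F)c1)c1nn(-c2ccccc2)ccc1=O`: 24900 nM

In a functional assay on HepG2 cells (Homo sapiens) for cytotoxicity, read by MTT assay, with a stated time of 72 h (on this read-out lower numbers stand for stronger inhibition and higher numbers for weaker inhibition), compound 1 gives 17800 nM, the lowest of the two numbers. Compound 2 gives 24900 nM, and the step of a 1.4-fold higher number from compound 1 to compound 2 (0.15 log units; within the scatter) lies within the scatter. Compound 3 `Cn1ccc2c(Oc3ccc(NC(=O)c4nn(-c5ccccc5)ccc4=O)cc3)ccnc21` differs from compound 1 by methyl in place of hydrogen on an aromatic nitrogen. For the measured compounds named here, no measured step concerns this position; the one step seen, fluoro replacing hydrogen on an aromatic carbon, was within the scatter and offers no direct guide. A step of at most modest size, in either direction or none beyond the scatter, is therefore expected in this assay. For compound 3 the estimate is 25000 nM, with a range from 9000 nM to 70000 nM, meaning an expected step of a 1.4-fold higher number from compound 1 to compound 3 (0.15 log units; within the scatter).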

Compound 3, half-maximal inhibitory concentration: 56200 nM
Beside the measured number, compound 3's estimate is 2.2-fold (0.35 log units) below it; the range from low to high includes it.
By their numbers in this assay, from the lowest: compounds 1 and 2 (each within the scatter of the next); then compound 3.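

Methyl in place of hydrogen on an aromatic nitrogen of the five-membered ring is the first single change in this assay to go beyond the scatter, with a 3.2-fold higher number from compound 1 to compound 3 (0.50 log units; beyond the scatter) as its step. The only earlier step, a 1.4-fold higher number from compound 1 to compound 2 (0.15 log units; within the scatter), lay within the scatter and concerned an aromatic carbon, so this nitrogen is the one place shown where the number responds to a change. Nothing measured here accounts for this step.

Going by these compounds, whether an ethyl group, a longer chain or a chain ending in an amine on this nitrogen would give a larger step remains open. So does whether methyl gives a similar step when the fluoro of compound 2 is present.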